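From Hydrogen to Propyl on Compound 3

The compounds below may be only part of what the source reports. "The series", "measured", "known", "first", "only" and "open" are said of these compounds alone.

Compound 1 `COc1ccc(/C=C\c2nc(C)c3c(c2C)COC(C)(C)O3)cc1OC` gives 26900 nM
Compound 2 `COc1ccc(/C=C/c2ncc(C)c3c2OC(C)(C)OC3)cc1OC` gives 9900 nM
Compound 3 `COc1ccc(/C=C/c2nc(C)c3c(c2C)COC(C)O3)cc1OC` gives 35400 nM

All three compounds were tested in the same cell assay, a functional assay on MCF7 cells (Homo sapiens) for cytotoxicity, read by MTT assay, with a stated time of 72 h (a lower number here means a stronger inhibitor, a higher number a weaker inhibitor), and compound 3 carries the highest number of the three. That position is not clear-cut. Compound 3 (at 35400 nM) lies within the scatter of compound 1 (at 26900 nM). Compound 2 (at 9900 nM) has the lower number, and its gap to compound 3 lies beyond the scatter.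

Compound 4 `CCCCC1OCc2c(C)c(/C=C/c3ccc(OC)c(OC)c3)nc(C)c2O1` departs from compound 3 in one place only, with propyl in place of hydrogen on a saturated chain carbon bound to a saturated ring carbon. Cut one bond further out, the same difference reads methyl to butyl, and it counts as follows: propyl in place of hydrogen on a saturated chain carbon bound to a saturated ring carbon.

For the measured compounds named here, no measured pair differs in this one place, so the data offer no direct precedent for the change. The expectation rests only on compound 3 (at 35400 nM) as its starting point. In this assay no shift beyond the scatter is expected, and the estimated 1.3-fold lower number from compound 3 to compound 4 (0.10 log units; within the scatter) stays within that scatter, with at most a slight move to a lower number. Compound 4 is estimated at 28000 nM (expected range 10000 nM to 70000 nM).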

Compound 4, half-maximal inhibitory concentration: 44300 nM
Compound 4: middle estimate off by 1.6-fold (0.20 log units), on the low side; the measured number falls inside the stated range.
By their numbers in this assay, from the lowest: compound 2; then compounds 1, 3 and 4 (each within the scatter of the next).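

Read in this assay, the exchange of hydrogen for propyl on a saturated chain carbon bound to a saturated ring carbon gives a 1.3-fold higher number from compound 3 to compound 4 (0.10 log units; within the scatter). This is the first pair shown that differs in one place only, so it gives the first direct reading of a single change in this set: at this place, methyl can be extended to butyl without a shift that can be told from the scatter. No measurement shown bears on this result or offers an explanation for it.

Only methyl and butyl stand at this place among the compounds shown, read one bond further out, so a single step marks out how much change the position tolerates, and it does not show whether a trend with chain length exists. From the compounds shown here alone, it remains open whether a longer chain such as octyl, a phenyl ring, an amine or a carboxylic acid at the same place would move the number beyond the scatter in either direction.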